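The compounds below may be only part of what the source reports. "The series", "measured", "known", "first", "only" and "open" are said of these compounds alone.

Measured so far in a functional assay on MCF7 cells (Homo sapiens) for cytotoxicity; a lower number here means a stronger inhibitor, a higher number a weaker inhibitor:
- compound 1, `O=C1NC(=O)c2c1c1c3ccccc3ccc1c1c2c2ccccc2n1[C@H]1OC[C@@H](O)[C@@H](O)[C@H]1O`: 4800 nM
- compound 2, `O=C1NC(=O)c2c1c1c3ccccc3ccc1c1c2c2ccccc2n1[C@@H]1O[C@H](CO)[C@@H](O)[C@H]1O`: 5300 nM

Compound 2 has the highest of the two numbers in this assay, but its nearest neighbour, compound 1, lies within the scatter, so the two cannot be ordered. Going by the values given here, the only step between measured compounds, a 1.1-fold higher number from compound 1 to compound 2 (0.04 log units; within the scatter), exchanges the whole six-membered ring on the aromatic nitrogen for a five-membered one and moves the number hardly at all.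

Compound 3, `O=C1NC(=O)c2c1c1c3ccccc3ccc1c1c2c2ccccc2n1[C@H]1C[C@H](O)[C@@H](CO)O1`, differs from compound 2 by hydrogen in place of hydroxy on a saturated ring carbon. Among the compounds with values here, no measured step removes a single hydroxy from the sugar ring, so this change has no direct precedent here; the one step that does exist shows the sugar portion tolerating a large exchange without a shift in this assay. The expectation is therefore a step of no change at the digits printed from compound 2 to compound 3 (within the scatter), nothing beyond the scatter. Compound 3 is expected near 5300 nM, with a range of 2500 nM to 11000 nM.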

Compound 3, half-maximal inhibitory concentration: 7300 nM
Beside the measured number, compound 3's estimate is 1.4-fold (0.14 log units) below it, within the range that was stated.
By their numbers in this assay, from the lowest: compounds 1, 2 and 3 (each within the scatter of the next).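

In this assay, going by these compounds alone, hydrogen in place of hydroxy on a saturated ring carbon of the five-membered ring is the first exchange of a single sugar group, and it stays within the scatter (a 1.4-fold higher number from compound 2 to compound 3 (0.14 log units; within the scatter)). The wider exchange, a 4-hydroxy-5-(hydroxymethyl)oxolan-2-yl group on the aromatic nitrogen in place of the six-membered group of compound 1, also stays within the scatter (a 1.5-fold higher number from compound 1 to compound 3 (0.18 log units; within the scatter)), so neither this hydroxy nor the ring exchange separates these compounds here. No measurement on hand explains this flat response.

On these data alone, whether any group at this ring carbon can move the number remains open, for example an amine or a methoxy group. Also open, as far as these compounds go, is whether an amine or a carboxylic acid in place of the hydroxymethyl group would do so.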